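This account rests on a few compounds, and the source may have more. Where it says the series, first, only, none or still open, it means among the compounds named here.

Compound 2, `COCCN1C(N)=NC(N)=NC12CCN(C(=O)NC1CCC(C)CC1)CC2`, is the starting point. In an ADME assay on MDCK cells (Canis lupus familiaris) for cytotoxicity, read by microscopy, with a stated time of 6 days (a lower number here means that less compound is tolerated, a higher number that more compound is tolerated), compound 2 gives > 100000 nM, which is a limit of the assay rather than a measured number. Compound 1, `COCCN1C(N)=NC(N)=NC12CCN(C(=O)C1CC1)CC2`, shares the same core and differs only at the carbonyl carbon. In this assay compound 1 gives > 100000 nM, again a limit. The step that the two limits leave unreadable from compound 1 to compound 2 therefore cannot be sized, because of the limit of > 100000 nM in this assay, at which 2 of the 2 values shown sit. Compound 3 is `COCCN1C(N)=NC(N)=NC12CCN(C(=O)Nc1ccc(OC)cc1)CC2`. The change from compound 2 is 4-methoxyphenyl in place of 4-methylcyclohexyl on an amide-type nitrogen. Among the measured compounds shown here, no measured step covers a change of this kind, so the expectation rests on the limits alone: both known compounds are tolerated up to the top of the tested range, and a step of unknown direction cannot be read from them. Compound 3 is expected to show an estimated step of a number no higher from compound 2 to compound 3 (the limit leaves the size open). The estimate for compound 3 is 100000 nM, with a range from 40000 nM to 300000 nM.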

Compound 3, minimum cytotoxic concentration: > 100000 nM
Compound 3: a limit, no number (the forecaster's own chance of this, stated with the estimate: 80%); the middle value sits exactly at the limit.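

Among the compounds shown here, no step among compound 1, compound 2 and compound 3 can be read, because all three stop at the same limit: the limit of > 100000 nM in this assay, at which 3 of the 3 values shown sit. The compounds shown leave open at what concentration each would become toxic in this assay, and whether these group changes alter tolerance at all.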